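This account rests on a few compounds, and the source may have more. Where it says the series, first, only, none or still open, it means among the compounds named here.

Measured in an ADME assay on cells (Hepatocyte, Homo sapiens) for metabolic stability; a lower number here means that the compound disappears faster, a higher number that the compound lasts longer:
- compound 1 `O=c1cc(N2CCN(CC3CCC(NS(=O)(=O)c4ccccc4)CC3)CC2)sc2c([N+](=O)[O-])cc(C(F)(F)F)cc12`: > 1.55 h (a limit)
- compound 2 `O=C(NC1CCC(CN2CCN(c3cc(=O)c4cc(C(F)(F)F)cc([N+](=O)[O-])c4s3)CC2)CC1)c1ccccc1`: > 1.55 h (a limit)
- compound 3 `COc1ccc(C(=O)OC2CCC(CN3CCN(c4cc(=O)c5cc(C(F)(F)F)cc([N+](=O)[O-])c5s4)CC3)CC2)cc1`: 0.165 h

Within the data shown here, compound 3 gives the only actual number, 0.165 h. The other two compounds both stand at the limit of > 1.55 h in this assay, at which 2 of the 3 values shown sit. The measured steps down to compound 3 are an at least 9.3-fold lower number from compound 1 to compound 3 (0.97 log units; beyond the scatter) and an at least 9.3-fold lower number from compound 2 to compound 3 (0.97 log units; beyond the scatter). In both, ((4-methoxyphenyl)carbonyl)oxy takes the place of a group attached through an amine nitrogen.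

The next compound is compound 4 `O=C(OC1CCC(CN2CCN(c3cc(=O)c4cc(C(F)(F)F)cc([N+](=O)[O-])c4s3)CC2)CC1)c1cccs1`, with the change thiophen-2-yl in place of 4-methoxyphenyl on a carbonyl carbon. The carbonyl-oxy link stays, now as ((thiophen-2-yl)carbonyl)oxy, so compound 4 is expected to remain in the range of compound 3 at 0.165 h. Among the measured compounds shown here, no measured step isolates this aromatic ring change. The expected result in this assay is therefore no shift beyond the scatter, with an estimated 1.1-fold higher number from compound 3 to compound 4 (0.04 log units; within the scatter). The expected half-life of compound 4 is 0.18 h, with an estimated range of 0.07 h to 0.5 h.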

Compound 4, half-life: 0.0917 h
Compound 4: the middle estimate sits 2.0-fold (0.29 log units) above what was measured, within the range that was stated.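

In this assay, thiophen-2-yl can stand in place of 4-methoxyphenyl on the carbonyl carbon with no shift beyond the scatter: a 1.8-fold lower number from compound 3 to compound 4 (0.26 log units; within the scatter). The short half-life now appears with two different aromatic rings on the carbonyl-oxy link, and the drop from the amine-linked compounds holds for the second ring as well: an at least 16-fold lower number from compound 2 to compound 4 (1.22 log units; beyond the scatter), and an at least 16-fold lower number from compound 1 to compound 4 (1.22 log units; beyond the scatter). Both of these steps are lower bounds, because compound 1 and compound 2 give only limits: the limit of > 1.55 h in this assay, at which 2 of the 4 values shown sit.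

Going by these compounds, how a carbonyl-oxy link would behave with a saturated group such as cyclohexyl or a short alkyl chain on its carbonyl carbon remains open. Also open, on these data alone, is whether an amide carrying thiophen-2-yl in place of phenyl would stay level with compound 2, or how an ether link would compare.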